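Working notes: from compound 3 to compound 4

The compounds below may be only part of what the source reports. "The series", "measured", "known", "first", "only" and "open" are said of these compounds alone.

The series is followed in an assay for inhibition of Amine oxidase [flavin-containing] A (Bos taurus), read by fluorescence, with a stated time of 60 min; a higher number here means a weaker inhibitor, a lower number a stronger inhibitor. Among the measured compounds shown here, compound 1 `O=C(NNc1nc2ccccc2nc1Cc1ccccc1)c1ccc(O)cc1` gives 1.7 nM and compound 2 `O=C(NNc1nc2ccccc2nc1Cc1ccccc1)c1ccc(Br)cc1` gives 74 nM; the only single-point step between measured compounds runs a 44-fold higher number from compound 1 to compound 2 (1.64 log units; beyond the scatter). Compound 3 `Cc1ccc(C(=O)NNC(=O)Cn2c(=O)c(Cc3ccccc3)nc3ccccc32)cc1` gives 52 nM, the second highest of the three numbers: compound 2 lies nearest, within the scatter, and compound 1 lies furthest, beyond it.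

Compound 4 `O=C(Cn1c(=O)c(Cc2ccccc2)nc2ccccc21)N/N=C1/C(=O)Nc2ccccc21` has not been measured. It differs from compound 3 in one place: a group of 11 heavy atoms (8 carbon, 2 nitrogen, 1 oxygen; one five-membered non-aromatic ring with 1 hetero atom, one six-membered aromatic ring of carbon only) in place of a group of 10 heavy atoms (8 carbon, 1 nitrogen, 1 oxygen; one six-membered aromatic ring of carbon only), on an amide-type nitrogen. For the measured compounds named here, no measured step covers this change. Going by the values given here, the one step in hand, bromo in place of hydroxy on an aromatic carbon, sits on the other core and on a different position, and shows only that a change at the outer ring can move the number well beyond the scatter. The direction for compound 4 therefore cannot be read from the data, and the step from compound 3 is expected to be small, a 1.3-fold lower number from compound 3 to compound 4 (0.11 log units; within the scatter), with a wide uncertainty. The estimate for compound 4 is 40 nM, expected to fall between 5 nM and 300 nM.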

Compound 4, half-maximal inhibitory concentration: 7.3 nM
Estimate against measurement, compound 4: 5.5-fold (0.74 log units) above, within the range that was stated.
By their numbers in this assay, from the lowest: compound 1; then compound 4; then compounds 3 and 2 (each within the scatter of the next).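

At the amide-type nitrogen whose other neighbour is a carbonyl carbon, the group on the core of compound 3 is not a neutral choice in this assay: the swap of ((4-methylphenyl)carbonyl)amino for the group with the five-membered non-aromatic ring gives a 7.1-fold lower number from compound 3 to compound 4 (0.85 log units; beyond the scatter) and lies beyond the scatter. Among the compounds shown here, the earlier compounds offered no step on this core, so this is the first sign that the number responds to a change at this place on it, and not only on the core of compound 1. The swap changes several things at once, since the entering group has a different ring set, 2 double bonds outside aromatic rings against 1, and 2 hydrogen-bond acceptors against 1, and nothing in hand connects any of these to the step.

On these data alone, with a single step on this core, it remains open which part of the entering group carries the change, and a version with the benzene ring removed would separate ring from chain. As far as these compounds go, it is also open how a carboxylic acid or an amine in place of the methyl of compound 3 would read in this assay on this core.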